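Caco-2 notes: methoxy for methyl on the aromatic ring

The source may report more compounds than this note shows. Statements on the series, on what has been measured and on what is new or still open speak of the compounds shown alone.

Values from an ADME assay on Caco-2 cells (Homo sapiens) for permeability, read by LC-MS, with a stated time of 2 h (a higher number here means that the compound crosses the layer faster, a lower number that the compound crosses the layer more slowly), so far
- compound 1 `Cc1cc(CN(C)C(CC(=O)O)c2ccc(Cl)cc2)ccc1OCCn1c(=O)ccn(C)c1=O` gives 0.6 nm/s
- compound 2 `CCN(Cc1ccc(OCCn2c(=O)ccn(C)c2=O)c(C)c1)C(CC(=O)O)c1ccc(Cl)cc1` gives 2.1 nm/s
- compound 3 `Cc1cc(CN(C2CCC2)C(CC(=O)O)c2ccc(Cl)cc2)ccc1OCCn1c(=O)ccn(C)c1=O` gives 5 nm/s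

Compound 3 gives 5 nm/s as the highest of the three numbers, clear of the scatter from both others. Next comes compound 4 `COc1cc(CN(C2CCC2)C(CC(=O)O)c2ccc(Cl)cc2)ccc1OCCn1c(=O)ccn(C)c1=O` with methoxy in place of methyl on an aromatic carbon in the shared core. The measured steps are a 3.5-fold higher number from compound 1 to compound 2 (0.54 log units; beyond the scatter) and a 2.4-fold higher number from compound 2 to compound 3 (0.38 log units; beyond the scatter) and also an 8.3-fold higher number from compound 1 to compound 3 (0.92 log units; beyond the scatter) but all of these concern the amine nitrogen and its substituents. None measures a change on the aromatic carbon, so no step beyond the scatter is expected in this assay in either direction. The estimated step is a 1.3-fold lower number from compound 3 to compound 4 (0.10 log units; within the scatter) on this reading. Compound 4 is expected at 4 nm/s with an estimated range of 1.7 nm/s to 9.5 nm/s in this assay.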

Compound 4, apparent permeability: 1.7 nm/s
The estimate for compound 4 lay 2.4-fold (0.37 log units) above the measured number; low and high end bracket the measured number.
By their numbers in this assay, from the lowest: compound 1; then compounds 4 and 2 (each within the scatter of the next); then compound 3.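

In this assay, methoxy in place of methyl on this aromatic carbon gives a 2.9-fold lower number from compound 3 to compound 4 (0.47 log units; beyond the scatter), so a change away from the amine nitrogen also moves the number beyond the scatter. This step also runs downward, while the steps among the amine nitrogen substituents all run upward from compound 1 to compound 3. No measurement at hand explains the drop.

Going by these compounds, whether the step carries over to the ethyl or methyl amines remains open. So does the outcome with hydrogen, fluorine or ethoxy on this aromatic carbon.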